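Alkyl variation on the ring nitrogen: cytotoxicity notes

This account rests on a few compounds, and the source may have more. Where it says the series, first, only, none or still open, it means among the compounds named here.

Compound 1 `CC(C)CN(c1ccnc(Nc2ccc(C#N)cc2)n1)c1c(F)cc(-c2ccc(C#N)cc2)cc1F` and compound 2 `CCC(C)N(c1ccnc(Nc2ccc(C#N)cc2)n1)c1c(F)cc(-c2ccc(C#N)cc2)cc1F` share one core and differ only in the alkyl group on the nitrogen on an aromatic ring. In an ADME assay on MT4 cells (Homo sapiens) for cytotoxicity, read by MTT assay, with a stated time of 5 days (on this read-out lower numbers stand for higher toxicity in this test and higher numbers for lower toxicity in this test), compound 1 gives 241000 nM and compound 2 gives 217000 nM; the pair shows a 1.1-fold lower number from compound 1 to compound 2 (0.05 log units; within the scatter). Compound 2 therefore sits with compound 1 inside the usual spread of this read-out, with no separation between the two numbers.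

Compound 3 `N#Cc1ccc(Nc2nccc(N(CC3CCCC3)c3c(F)cc(-c4ccc(C#N)cc4)cc3F)n2)cc1` is not yet measured; it carries cyclopentylmethyl in place of sec-butyl on a nitrogen on an aromatic ring. Within the data shown here, the only measured step that bears on this change is the swap from isobutyl to sec-butyl, which gave a 1.1-fold lower number from compound 1 to compound 2 (0.05 log units; within the scatter) in this assay. A further exchange among alkyl groups at the same nitrogen is thus expected to move the number little, and the expected step is a 1.1-fold lower number from compound 2 to compound 3 (0.04 log units; within the scatter), none beyond the scatter. On this basis compound 3 is estimated at 200000 nM in this assay, with a range from 80000 nM to 400000 nM.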

Compound 3, half-maximal cytotoxic concentration: > 247000 nM
Compound 3: no number, only a limit; the forecaster's own chance of this, stated with the estimate: 20%; middle value at least 1.2-fold (0.09 log units) away from the limit.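

In this assay compound 3 is recorded only as a limit, not a number: the limit of > 247000 nM in this assay, at which 1 of the 3 values shown sits. The steps can therefore be read only as floors, an at least 1.1-fold higher number from compound 2 to compound 3 (0.05 log units; that floor lies within the scatter) and an at least 1.0-fold higher number from compound 1 to compound 3 (0.01 log units; that floor lies within the scatter), so no separation among the three compounds is established. Among these compounds, what is new at this position is that cyclopentylmethyl, with its five-membered non-aromatic ring of carbon only, shows no step towards a lower number from the ring-free sec-butyl and isobutyl groups.

From the compounds shown here alone, how far the true value of compound 3 lies past its limit stays open. The compounds shown also leave open whether an amine, a carboxylic acid or a longer chain on this nitrogen on an aromatic ring would move the number beyond the scatter.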